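Hydroxy addition on the sugar ring of compound 2

This account rests on a few compounds, and the source may have more. Where it says the series, first, only, none or still open, it means among the compounds named here.

Compound 1 `Cc1nsc2[nH]c(SCc3ccccc3)nc12`: 9000 nM
Compound 2 `Cc1nsc2c1nc(SCc1ccccc1)n2[C@H]1C[C@H](O)[C@@H](CO)O1`: > 100000 nM (a limit)
Compound 3 `OC[C@H]1O[C@@H](n2c(SCc3ccccc3)nc3cnsc32)C[C@@H]1O`: > 100000 nM (a limit)

In a functional assay on KB cells (Homo sapiens) for antiproliferative activity (a lower number here means a stronger inhibitor, a higher number a weaker inhibitor), compound 1 gives 9000 nM. For compound 2 this assay reports only a limit, > 100000 nM. Compound 3 likewise gives only a limit, > 100000 nM. Two of the three values sit at the limit of > 100000 nM in this assay, at which 2 of the 3 values shown sit, so compound 2 stands at the unreadable end of the numbers shown. Compound 4 `Cc1nsc2c1nc(SCc1ccccc1)n2[C@@H]1O[C@H](CO)[C@@H](O)[C@@H]1O` differs from compound 2 by hydroxy in place of hydrogen on a saturated ring carbon. Going by the values given here, the one readable step bearing on it is an at least 11-fold higher number from compound 1 to compound 2 (1.04 log units; beyond the scatter); the step that the two limits leave unreadable from compound 2 to compound 3. Among the compounds with values here, no measured step tells how a hydroxy on the sugar ring acts. Compound 4 is therefore expected to return a limit again, estimated at 100000 nM in this assay, within 30000 nM to 300000 nM. The expected step is a number no higher from compound 2 to compound 4 (the limit leaves the size open), within the scatter.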

Compound 4, half-maximal inhibitory concentration: > 100000 nM
Compound 4 was reported as a limit (the forecaster's own chance of this, stated with the estimate: 85%); the middle value lies on the limit itself.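

Compound 2 and compound 4 both return only a limit in this assay, so no step between them can be read: the limit of > 100000 nM in this assay, at which 3 of the 4 values shown sit.

Whether hydroxy in place of hydrogen on the saturated ring carbon changes activity at all stays open among the compounds shown.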